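The source may hold more compounds than are shown below. What is called first, only, known or untested is meant among the compounds shown, and "the series" means these compounds.

Of the compounds shown here, two have so far been measured in a functional assay on CHO-K1 cells for antagonist activity at Urotensin-2 receptor (Rattus norvegicus), read by FLIPR and calcium flux; a higher number here means a weaker inhibitor, a lower number a stronger inhibitor. Compound 1 `CC(C)(C)OC(=O)N1CCC(CNC(=O)c2ccccc2C2CCN(CCN3C(=O)COc4ccccc43)CC2)CC1` gives 2500 nM. Compound 2 `O=C(NCC1CCN(S(=O)(=O)Cc2ccccc2)CC1)c1cc(Cl)ccc1C1CCN(CCN2C(=O)COc3ccccc32)CC1` gives 53 nM, the lower of the two numbers, and its gap to compound 1 lies well beyond the usual scatter. Compound 3 `CC(C)(C)CC(=O)N1CCC(CNC(=O)c2cc(Cl)ccc2C2CCN(CCN3C(=O)COc4ccccc43)CC2)CC1` differs from compound 2 in one place: neopentylcarbonyl in place of benzylsulfonyl on an amine nitrogen in a ring. Going by the values given here, no measured pair shows this change by itself, and compound 1 differs from compound 2 in more than one place, so the size of the step cannot be read from the data. The change is estimated to weaken inhibition moderately, a 5.7-fold higher number from compound 2 to compound 3 (0.75 log units; beyond the scatter). Compound 3 is expected to give 300 nM, within a range from 60 nM to 1500 nM.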

Compound 3, half-maximal inhibitory concentration: 330 nM
The estimate for compound 3 lay 1.1-fold (0.04 log units) below the measured number; the measured number falls inside the stated range.
By their numbers in this assay, from the lowest: compound 2; then compound 3; then compound 1.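

In this assay, going by these compounds alone, neopentylcarbonyl in place of benzylsulfonyl on the amine nitrogen in the ring gives a 6.2-fold higher number from compound 2 to compound 3 (0.79 log units; beyond the scatter) and provides the first direct reading of a change at this position. The result shows that the group on this nitrogen affects the measured inhibition, with benzylsulfonyl giving the lower number of this pair. Still open, from the compounds shown here alone, is whether the sulfonyl link or the benzyl ring matters more, and how a phenylacetyl group or a longer chain would compare. No measurement here explains the step.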